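The compounds below may be only part of what the source reports. "The series", "measured", "known", "first", "only" and "open" are said of these compounds alone.

Compound 1 `COc1ccc(-c2nsc3c2NC(=O)CC3c2ccc3c(c2)OCCO3)cc1`: 659 nM
Compound 2 `COc1ccc(-c2nsc3c2NC(=O)CC3c2cccc(Cl)c2)cc1`: 1270 nM

In a functional assay on TOV112D cells (Homo sapiens) for antiproliferative activity, read by CellTiter-Glo, with a stated time of 96 h (a lower number here means a stronger inhibitor, a higher number a weaker inhibitor), compound 2 gives 1270 nM, and its nearest neighbour, compound 1, gives 659 nM. These two values lie within the scatter of each other, so compound 2 stands level with compound 1.

Compound 3 `COc1ccc(-c2nsc3c2NC(=O)CC3c2ccc(F)cc2)cc1` keeps the shared core but carries 4-fluorophenyl in place of 3-chlorophenyl on a saturated ring carbon, three ring bonds from the ring nitrogen: 4-fluorophenyl in place of 3-chlorophenyl on a saturated ring carbon. Both groups hold one six-membered aromatic ring of carbon only. Among the compounds with values here, no measured pair differs in just one place, so the data offer no direct measure of such a swap. The step expected in this assay is therefore none beyond the scatter, in either direction. Compound 3 is estimated at 1100 nM, with an expected range of 450 nM to 2800 nM.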

Compound 3, half-maximal inhibitory concentration: > 2000 nM
Compound 3: no number, only a limit; the forecaster's own chance of this, stated with the estimate: 5%; middle value at least 1.8-fold (0.25 log units) from the limit.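

In this assay compound 3 gives > 2000 nM, which is a limit of the assay and not a number. Putting 4-fluorophenyl in place of 3-chlorophenyl on a saturated ring carbon gives an at least 1.5-fold higher number from compound 2 to compound 3 (0.19 log units; that floor lies within the scatter), the first direct one-place measure at this position, and it shows no gain in strength. The true size of the step stays unknown, since a floor does not say how far the number rises, and the only evidence that bears on this is the following: the limit of > 2000 nM in this assay, at which 1 of the 3 values shown sits.

This swap alters both the halogen and its place on the aromatic ring, and the compounds shown cannot separate the two, which 3-fluorophenyl or 4-chlorophenyl on the same carbon could do. Also open, as far as these compounds go, is how this position responds to a group without an aromatic ring, such as cyclohexyl or an amine.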